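Swapping fluoro for carbamoyl on an inactive compound

A few compounds are considered here, and "the series" means these few. Any claim that something is new, unique, unknown or untested is made for them only; others in the source may bear on it.

Measured so far in a functional assay on A549 cells (Homo sapiens) for antiproliferative activity, read by CCK-8 assay, with a stated time of 72 h; a lower number here means a stronger inhibitor of growth, a higher number a weaker inhibitor of growth
compound 1 `CC[C@@H]1C(=O)N(C)c2cnc(-n3ccc4cc(C(N)=O)ccc43)nc2N1C1CCCC1` gives 4350 nM
compound 2 `CCC1C(=O)N(C)c2cnc(-n3ccc4cc(F)ccc43)nc2N1c1ccn(C)n1` gives "not active" (no number reported)
compound 3 `CC[C@@H]1C(=O)N(C)c2cnc(-n3ccc4cc(C(=O)NCC(C)C)ccc43)nc2N1C1CCCC1` gives 1730 nM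

In this assay, for the measured compounds named here, compound 2 stands at "not active" (no number reported), so no step can be counted from it. Compound 4 `CCC1C(=O)N(C)c2cnc(-n3ccc4cc(C(N)=O)ccc43)nc2N1c1ccn(C)n1` has carbamoyl in place of fluoro on an aromatic carbon. Going by the values given here, the only measured step, a 2.5-fold lower number from compound 1 to compound 3 (0.40 log units; beyond the scatter), is modest and comes from isobutyl in place of hydrogen on an amide-type nitrogen, so it does not test this swap. Compound 4 differs elsewhere from compound 1, which shares the carbamoyl and gives 4350 nM. A measurable number is therefore expected, though compound 4 may stay inactive, and the size of the step cannot be stated. For compound 4 the expected value is 6000 nM, with an estimated range of 1800 nM to 20000 nM.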

Compound 4, concentration for 50% growth inhibition: 39500 nM
The estimate for compound 4 lay 6.6-fold (0.82 log units) below the measured number, outside the stated range (above it).
By their numbers in this assay, from the lowest: compound 3; then compound 1; then compound 4.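

For the compounds shown here, compound 2 has no number in this assay, so no step to compound 4 at 39500 nM can be read. No evidence here bears on this result. Going by these compounds, how far carbamoyl in place of fluoro shifts growth inhibition remains open.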